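Methyl on the alkyne: from an unreadable step to a guess

A few compounds are considered here, and "the series" means these few. Any claim that something is new, unique, unknown or untested is made for them only; others in the source may bear on it.

Compound 1 `C#CCNC(=O)c1cccc2c1cc(C)n2-c1nc2c(c(NCc3ccccc3)n1)CCCC2` and compound 2 `CC#CCNC(=O)c1cccc2c1cc(C)n2-c1nc2c(c(NCc3ccccc3)n1)CCCC2` share a core and differ only in methyl in place of hydrogen on a triple-bonded carbon. In a physicochemical assay for pharmacokinetics, read by LC-MS, in phosphate buffer, tested at 1 uM (on this read-out lower numbers stand for a shorter-lived compound and higher numbers for a longer-lived compound), compound 1 gives > 24 h, which is a limit of the assay rather than a number. In this assay compound 2 likewise gives > 24 h, again a limit and not a number. The step that the two limits leave unreadable from compound 1 to compound 2 therefore cannot be sized, because of the limit of > 24 h in this assay, at which 2 of the 3 values shown sit.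

Compound 3 `C#CC(=O)Nc1cccc2c1cc(C)n2-c1nc2c(c(NCc3ccccc3)n1)COCC2` carries a different core; the difference between the two cores is not broken down here. In this assay, among the measured compounds shown here, compound 3 gives 0.21 h, the only plain number in the set. Compound 4 `CC#CC(=O)Nc1cccc2c1cc(C)n2-c1nc2c(c(NCc3ccccc3)n1)COCC2` is not yet measured and differs from compound 3 by methyl in place of hydrogen on a triple-bonded carbon, the same change that separates compound 1 from compound 2, at a place described in the same words.

Because the step that the two limits leave unreadable from compound 1 to compound 2 is hidden behind the limit, it gives no size to carry over. For compound 4 the expected step is a 7.1-fold higher number from compound 3 to compound 4 (0.85 log units; beyond the scatter), an estimate resting only on the short value of compound 3 and on the fact that compound 2 is not shorter-lived than the limit allows to tell. The expected half-life of compound 4 is 1.5 h, likely between 0.3 h and 8 h.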

Compound 4, half-life: 16.2 h
Compound 4: the middle estimate sits 11-fold (1.03 log units) below what was measured; measured number above the stated range.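

In this assay the new pair gives a 77-fold higher number from compound 3 to compound 4 (1.89 log units; beyond the scatter), so on the core of compound 3, methyl in place of hydrogen on a triple-bonded carbon goes with a much longer half-life. The same change on the core of compound 1 offers nothing to set beside this step, because neither member of that pair gives a readable number: the limit of > 24 h in this assay, at which 2 of the 4 values shown sit. The result therefore shows that this small change can matter a great deal on one core, but it does not show that a step of this size, or even its direction, carries from one core to the other, since a single readable step makes no pattern.

Still open, going by these compounds, is what other groups on the same triple-bonded carbon would do on the core of compound 3, such as a longer chain like ethyl or an amine like dimethylaminomethyl. Also open, on these data alone, is whether either would give a half-life closer to that of compound 3 or to that of compound 4.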